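The source may report more compounds than this note shows. Statements on the series, on what has been measured and on what is new or still open speak of the compounds shown alone.

Measured compounds:
Compound 1 `Clc1ccc(/C=N/c2sc3c(c2-c2nc4ccccc4s2)CCC3)cc1` — 342 ug/mL
Compound 2 `Fc1ccccc1/C=N/c1sc2c(c1-c1nc3ccccc3s1)CCC2` — 270 ug/mL

In an ADME assay on cells (Rhabdomyosarcoma cell, Homo sapiens) for cytotoxicity, read by MTT assay, with a stated time of 72 h (a higher number here means that more compound is tolerated, a lower number that less compound is tolerated), compound 1 gives 342 ug/mL and compound 2 gives 270 ug/mL. Compound 2 holds the lower of the two numbers, but the step that separates them is a 1.3-fold lower number from compound 1 to compound 2 (0.10 log units; within the scatter), so the two cannot be told apart on this evidence. Compound 3 `Clc1ccccc1/C=N/c1sc2c(c1-c1nc3ccccc3s1)CCC2` is not yet measured. It differs from compound 2 by chloro in place of fluoro on an aromatic carbon. Going by the values given here, the only measured step that bears on this change is the one from compound 1 to compound 2, in which 2-fluorophenyl replaced 4-chlorophenyl on a carbon with a double bond to nitrogen; that step came to a 1.3-fold lower number from compound 1 to compound 2 (0.10 log units; within the scatter). Both measured compounds thus sit close together, whether the halogen is chloro or fluoro and whichever position it holds. Compound 3 is therefore expected to remain in the same region, with a step of a 1.1-fold higher number from compound 2 to compound 3 (0.04 log units; within the scatter) that stays within the scatter. The estimate for compound 3 in this assay is 295 ug/mL, within a range from 160 ug/mL to 540 ug/mL.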

Compound 3, half-maximal cytotoxic concentration: 123 ug/mL
Compound 3: the middle estimate sits 2.4-fold (0.38 log units) above what was measured, outside the stated range (below it).
By their numbers in this assay, from the lowest: compound 3; then compounds 2 and 1 (each within the scatter of the next).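

In this assay the halogen at this place, ortho to a large group, turns out to matter: chloro in place of fluoro gives a 2.2-fold lower number from compound 2 to compound 3 (0.34 log units; beyond the scatter) and so separates two compounds that differ in that one atom alone. The position of chloro on the phenyl ring matters as well, since 2-chlorophenyl in place of 4-chlorophenyl gives a 2.8-fold lower number from compound 1 to compound 3 (0.44 log units; beyond the scatter) and both of these modest steps lead to compound 3, which holds the lowest number of the three, whereas the earlier step, which changed the halogen and its position together, came to only a 1.3-fold lower number from compound 1 to compound 2 (0.10 log units; within the scatter) and gave no sign of either effect. Nothing measured here accounts for these differences.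

The compounds shown leave open how bromo, methoxy or an amine at the same place would compare with chloro and fluoro. They also leave open whether the step from fluoro to chloro would come out the same at other places on the phenyl ring or on a different core, since it is seen here only once, on the shared core.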